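The compounds below may be only part of what the source reports. "The series", "measured", "known", "first", "only" and "open" are said of these compounds alone.

Compound 1 has the structure `COc1ccc(Cl)cc1S(=O)(=O)Nc1ccc(-c2nc3ccccc3o2)cc1`. In an assay on cells for inhibition of HSP60/HSP10 (Homo sapiens), with a stated time of 60 min (a higher number here means a weaker inhibitor, a lower number a stronger inhibitor), compound 1 does not reach a measurable number; it is recorded only as the limit > 100000 nM. Compound 2, with the structure `O=S(=O)(Nc1ccc2oc(-c3ccccc3)nc2c1)c1ccc(Cl)c(C(F)(F)F)c1`, is likewise recorded in this assay only as the limit > 100000 nM. For the measured compounds named here, compound 1 therefore stands where everything measured here stands, at the limit of > 100000 nM in this assay, at which 2 of the 2 values shown sit, and no step between two measured compounds can be drawn from these values.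

Compound 3 has the structure `O=S(=O)(Nc1ccc(-c2nc3ccccc3o2)cc1)c1ccccc1F`. It differs from compound 1 in a single place: 2-fluorophenyl in place of 5-chloro-2-methoxyphenyl on a sulfonyl sulfur.

With both measured compounds sitting at the same limit, there is no numerical anchor for a change in either direction, so the expected step is a number no higher from compound 1 to compound 3 (the limit leaves the size open), none beyond the scatter. Compound 3 is accordingly expected to give about 100000 nM in this assay, most probably again reported only as a limit, with a range from 30000 nM to 300000 nM.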

Compound 3, half-maximal inhibitory concentration: > 100000 nM
Compound 3 was reported as a limit; the forecaster's own chance of this, stated with the estimate: 80%; the middle value lies on the limit itself.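

For the compounds shown here, compound 1 and compound 3 both give only a limit, not a number, so no step between them can be read: the limit of > 100000 nM in this assay, at which 3 of the 3 values shown sit. The compounds shown leave open how strongly any of them inhibits in this assay, and whether 2-fluorophenyl in place of 5-chloro-2-methoxyphenyl changes that at all.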